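A Third Methoxy Group Where Two Already Sit

The compounds below may be only part of what the source reports. "The series", "measured", "known", "first", "only" and "open" are said of these compounds alone.

Measured so far in a functional assay on HT-29 cells (Homo sapiens) for antiproliferative activity, with a stated time of 48 h; on this read-out lower numbers stand for stronger inhibition of growth and higher numbers for weaker inhibition of growth:
Compound 1 `Cc1cc(O)c(C2=NN(c3ccc(S(N)(=O)=O)cc3)C(c3ccccc3Cl)C2)cc1Cl`: 1920 nM
Compound 2 `COc1ccc(C2CC(c3cc(Cl)c(C)cc3O)=NN2c2ccc(S(N)(=O)=O)cc2)cc1OC`: 2240 nM

Compound 2 is the one of the two measured compounds whose number stands uppermost; the step of a 1.2-fold higher number from compound 1 to compound 2 (0.07 log units; within the scatter) is, however, within the scatter, so compound 1 and compound 2 cannot be told apart on these data.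

Compound 3 `COc1ccc(C2CC(c3cc(Cl)c(C)cc3O)=NN2c2ccc(S(N)(=O)=O)cc2)c(OC)c1OC` differs from compound 2 by a single change: methoxy in place of hydrogen on an aromatic carbon. Within the data shown here, the only measured step, that from compound 1 to compound 2, exchanged the whole group on that saturated ring carbon and still produced no shift beyond the scatter. Among the measured compounds shown here, this suggests that changes in that part of the molecule are tolerated, although no measured step tests an added methoxy group directly. The expected step is therefore a 1.0-fold lower number from compound 2 to compound 3 (0.01 log units; within the scatter), none beyond the scatter. Compound 3 is estimated at 2200 nM, expected to lie between 900 nM and 5500 nM.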

Compound 3, concentration for 50% growth inhibition: 1920 nM
Beside the measured number, compound 3's estimate is 1.1-fold (0.06 log units) above it, within the range that was stated.
By their numbers in this assay, from the lowest: compounds 1, 3 and 2 (each within the scatter of the next).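

In this assay, a third methoxy group on an aromatic carbon, ortho to a large group and ortho to a methoxy group, gives a 1.2-fold lower number from compound 2 to compound 3 (0.07 log units; within the scatter), so this position accepts a methoxy group with no shift beyond the scatter. Among these compounds, this is the first direct test of adding a group to this ring, where the earlier step exchanged the whole group. The wider exchange, 2,3,4-trimethoxyphenyl in place of 2-chlorophenyl, gives no change at the digits printed from compound 1 to compound 3 (within the scatter), so the three compounds cannot be told apart in this assay, and nothing available explains this tolerance.

The compounds shown leave open whether an amine or a carboxylic acid at this same position would also stay within the scatter. They also leave open whether a longer chain, such as butoxy, would be accepted there in place of methoxy.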